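The source may hold more compounds than are shown below. What is called first, only, known or untested is meant among the compounds shown, and "the series" means these compounds.

Measured in a functional assay on HT-29 cells (Homo sapiens) for antiproliferative activity, read by sulforhodamine B assay, with a stated time of 48 h; a higher number here means a weaker inhibitor, a lower number a stronger inhibitor:
- Compound 1 `CCCN1CCN(c2ccc(S(=O)(=O)Oc3ccccc3C)cc2)C1=O` gives > 100000 nM (a limit)
- Compound 2 `CCCN1CCN(c2ccc(S(=O)(=O)Oc3ccc(C)cc3C)cc2)C1=O` gives 26000 nM
- Compound 3 `CCCCN1CCN(c2ccc(S(=O)(=O)Oc3ccccc3)cc2)C1=O` gives > 100000 nM (a limit)

Compound 3 stands at the limit of > 100000 nM in this assay, at which 2 of the 3 values shown sit. This is a limit and not a number, so the size of any step from it stays uncertain.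

Compound 4 `CCCCN1CCN(c2ccc(S(=O)(=O)Oc3ccc(F)c(F)c3)cc2)C1=O` differs from compound 3 by having 3,4-difluorophenyl in place of phenyl on an oxygen whose other neighbour is the sulfonyl sulfur: 3,4-difluorophenyl in place of phenyl on an oxygen.

For the measured compounds named here, only one measured step bears on this change, and it also adds a group to the aromatic ring on that oxygen. That step is an at least 3.8-fold lower number from compound 1 to compound 2 (0.58 log units; beyond the scatter), with methyl in place of hydrogen on an aromatic carbon, and it lies beyond the scatter. It involves methyl rather than fluorine, so it is only a loose guide.

A modest move to a lower number is therefore expected in this assay, with the expected step being an at least 2.0-fold lower number from compound 3 to compound 4 (0.30 log units; that floor lies within the scatter). The estimated value for compound 4 is 50000 nM, with an estimated range of 15000 nM to 100000 nM.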

Compound 4, half-maximal inhibitory concentration: > 100000 nM
Compound 4: a limit, no number; the forecaster's own chance of this, stated with the estimate: 40%; middle value at least 2.0-fold (0.30 log units) away from the limit.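

Compound 3 and compound 4 each sit at a limit of the assay and not at a number, so no step between them can be read: the limit of > 100000 nM in this assay, at which 3 of the 4 values shown sit.

The compounds shown leave open whether 3,4-difluorophenyl in place of phenyl on an oxygen changes the result at all in this assay.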